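The source may report more compounds than this note shows. Statements on the series, on what has been measured and on what is new or still open speak of the compounds shown alone.

Compound 1 `CCO/N=C(\CCN1CCN(c2cccc(OC)c2)CC1)c1ccccc1` and compound 2 `CCO/N=C(\CCN1CCN(c2cccc(OCC)c2)CC1)c1ccccc1` were both examined in a functional assay on HEK293 cells with D(4) dopamine receptor (Homo sapiens) as the target, read by FLIPR; on this read-out lower numbers stand for smaller maximal responses and higher numbers for larger maximal responses. In this assay compound 1 gives 30%, while compound 2 reaches 84%. For the measured compounds named here, the single measured step, a number 54 percentage points higher from compound 1 to compound 2 (beyond the scatter), shows that a small change on the group attached to the ring nitrogen of the shared core moves the maximal response strongly. Among the two compounds measured, compound 2 stands highest, with compound 1 well below it, beyond the scatter.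

Compound 3 `CCO/N=C(\CCN1CCN(c2ncccc2C#N)CC1)c1ccccc1` has not yet been measured. Relative to compound 2 its change is 3-cyanopyridin-2-yl in place of 3-ethoxyphenyl on an amine nitrogen in a ring. Going by the values given here, no measured step concerns this kind of exchange: the only step known alters a substituent on the aromatic ring that is now removed, so it bears on the present change only in showing how sensitive this read-out is to alterations at that position of the core. On that basis a moderate step downward from compound 2 is expected for compound 3, namely a number 29 percentage points lower from compound 2 to compound 3 (beyond the scatter), with wide uncertainty. The expected value for compound 3 is therefore 55%, estimated to lie between 15% and 95%.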

Compound 3, largest response reached (reported as efficacy), in percent of the reference or control that the assay uses: 64%
For compound 3 the middle estimate is 9 percentage points below the measured one; the range from low to high includes it.
By their numbers in this assay, from the lowest: compound 1; then compound 3; then compound 2.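

In this assay, the exchange of the whole aromatic group on the amine nitrogen in a ring gives a number 20 percentage points lower from compound 2 to compound 3 (beyond the scatter), a modest step, whereas the same exchange made against the methoxy member gives a number 34 percentage points higher from compound 1 to compound 3 (beyond the scatter), a large one. The earlier pair showed only that the alkoxy chain on the phenyl ring can move the maximal response; compound 3 now shows that 3-ethoxyphenyl or 3-methoxyphenyl is not needed for a substantial response, since 3-cyanopyridin-2-yl places it between the two alkoxy compounds, beyond the scatter from each. No available evidence accounts for the size or direction of these steps.

The pyridine ring nitrogen and the nitrile enter together in compound 3, so their separate contributions remain unresolved, and a 3-cyanophenyl group or an unsubstituted pyridin-2-yl group would be needed to separate them. Also open, going by these compounds, is whether a longer chain, such as the propoxy group in 3-propoxyphenyl, would extend the rise seen from methoxy to ethoxy, or whether that rise stops at ethoxy.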